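A few compounds are considered here, and "the series" means these few. Any claim that something is new, unique, unknown or untested is made for them only; others in the source may bear on it.

In a functional assay on L1210 cells (Mus musculus) for antiproliferative activity (on this read-out higher numbers stand for weaker inhibition and lower numbers for stronger inhibition), three compounds have been measured:

Compound 1 `COc1ccc(-c2cc(N)c(C(=O)c3cc(OC)c(OC)c(OC)c3)s2)cc1OC`: 40 nM
Compound 2 `COc1cc(C(=O)c2sc(-c3ccncc3)cc2N)cc(OC)c1OC`: 1810 nM
Compound 3 `COc1cc(C(=O)c2sc(-c3ccccc3Cl)cc2N)cc(OC)c1OC`: 20 nM

Compound 3 stands level with compound 1, as shown by a 2.0-fold lower number from compound 1 to compound 3 (0.30 log units; within the scatter). It lies far from compound 2, as shown by a 91-fold lower number from compound 2 to compound 3 (1.96 log units; beyond the scatter).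

Compound 4 `COc1cc(C(=O)c2sc(-c3ccc(C)cc3)cc2N)cc(OC)c1OC` has 4-methylphenyl in place of 2-chlorophenyl on an aromatic carbon next to the ring sulfur: 4-methylphenyl in place of 2-chlorophenyl on an aromatic carbon. For the measured compounds named here, no measured step involves 4-methylphenyl itself, so the evidence comes from other swaps at this same carbon. Both large steps involve pyridin-4-yl in compound 2, namely a 45-fold higher number from compound 1 to compound 2 (1.66 log units; beyond the scatter) and a 91-fold lower number from compound 2 to compound 3 (1.96 log units; beyond the scatter). Going by the values given here, the only swap between two substituted phenyl groups is a 2.0-fold lower number from compound 1 to compound 3 (0.30 log units; within the scatter), and 4-methylphenyl is also a substituted phenyl. On these three compounds alone, no step beyond the scatter is expected in this assay, though a slightly higher number would not be surprising. The expected change is a 1.8-fold higher number from compound 3 to compound 4 (0.24 log units; within the scatter). The estimated value for compound 4 is 35 nM, with an expected range from 10 nM to 130 nM.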

Compound 4, half-maximal inhibitory concentration: 18 nM
Beside the measured number, compound 4's estimate is 1.9-fold (0.29 log units) above it; the range from low to high includes it.
By their numbers in this assay, from the lowest: compounds 4, 3 and 1 (each within the scatter of the next, the first and the last beyond it); then compound 2.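

In this assay, 2-chlorophenyl and 4-methylphenyl on this aromatic carbon next to the ring sulfur cannot be told apart, with a 1.1-fold lower number from compound 3 to compound 4 (0.05 log units; within the scatter), so the chlorine is not required for a number at this level. The gap to pyridin-4-yl now holds for a third substituted phenyl group, with a 100-fold lower number from compound 2 to compound 4 (2.00 log units; beyond the scatter). Against 3,4-dimethoxyphenyl the step is modest, with a 2.2-fold lower number from compound 1 to compound 4 (0.35 log units; beyond the scatter), and it is the first replacement of that group by a substituted phenyl to pass beyond the scatter. Nothing measured here explains these differences.

The compounds shown leave open how much the substituent's kind and its place on the phenyl ring each count, as chloro and methyl differ in both. They also leave open how an unsubstituted phenyl, or a phenyl carrying a carboxylic acid or an aminomethyl group, would read at this carbon.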